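Methyl in Place of Hydrogen on the Linker Carbon

A few compounds are considered here, and "the series" means these few. Any claim that something is new, unique, unknown or untested is made for them only; others in the source may bear on it.

Measured compounds:
compound 1 `CC1(C)CCC(C)(C)c2cc(NC(=O)c3ccc(C(=O)OCCCCCCOC(=O)c4ccc(OCc5c(-c6ccccc6)no[n+]5[O-])cc4)cc3)ccc21` gives 486000 nM
compound 2 `CC1(C)CCC(C)(C)c2cc(NC(=O)c3ccc(C(=O)NCC(=O)OCc4c(-c5ccccc5)no[n+]4[O-])cc3)ccc21` gives 160 nM
compound 3 `CC1(C)CCC(C)(C)c2cc(NC(=O)c3ccc(C(=O)OCCCCCOC(=O)c4ccc(OCc5c(-c6ccccc6)no[n+]5[O-])cc4)cc3)ccc21` gives 282000 nM

All three numbers come from a functional assay on HL-60 cells (Homo sapiens) for antiproliferative activity, read by MTT assay, with a stated time of 48 h; a lower number here means a stronger inhibitor, a higher number a weaker inhibitor. Compound 2 stands lowest of the three, and both other numbers lie far beyond the scatter from it: compound 3 is nearest, compound 1 furthest. Among the compounds with values here, compounds 1 and 3 carry a long ester-linked chain where compound 2 carries a short amide-linked one, but no pair of measured compounds differs in just one place, so no single change can be read from these numbers.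

Compound 4 `C[C@H](NC(=O)c1ccc(C(=O)Nc2ccc3c(c2)C(C)(C)CCC3(C)C)cc1)C(=O)OCc1c(-c2ccccc2)no[n+]1[O-]` differs from compound 2 in one place: methyl in place of hydrogen on a saturated chain carbon bound to an amide-type nitrogen and a carbonyl carbon. Within the data shown here, this adds one carbon and no donor or acceptor, and no measured pair isolates such a change. In this assay the step from compound 2 to compound 4 is expected to stay within the usual scatter, with no clear direction, so the expected step is a 1.1-fold higher number from compound 2 to compound 4 (0.05 log units; within the scatter). Compound 4 is therefore expected to give about 180 nM, with a range from 60 nM to 550 nM.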

Compound 4, half-maximal inhibitory concentration: 6970 nM
The estimate for compound 4 lay 39-fold (1.59 log units) below the measured number; the whole stated range lies below it.
By their numbers in this assay, from the lowest: compound 2; then compound 4; then compounds 3 and 1 (each within the scatter of the next).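

In this assay, the saturated chain carbon bound to an amide-type nitrogen and a carbonyl carbon proves highly sensitive to change: methyl in place of hydrogen gives a 44-fold higher number from compound 2 to compound 4 (1.64 log units; beyond the scatter). The earlier compounds shown here differed from one another in more than one place, so they could not show that this single carbon matters, or that adding just one carbon, with no donor or acceptor, can move the number this far. Nothing measured here explains the rise.

Still open, going by these compounds, is whether a larger group on this carbon, such as ethyl or benzyl, would raise the number further, or whether hydroxymethyl would behave differently. Also open, on these data alone, is whether the methyl would have the same effect with the opposite arrangement in space at this carbon.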